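Chain length on an amine nitrogen in a ring

The source may report more compounds than this note shows. Statements on the series, on what has been measured and on what is new or still open speak of the compounds shown alone.

For the measured compounds named here, in a functional assay on A2780 cells (Homo sapiens) for antiproliferative activity (on this read-out lower numbers stand for stronger inhibition and higher numbers for weaker inhibition), compound 1 `Cc1ccc2c(c1C)CN(C(C)C)CC2c1ccccc1` gives 6280 nM and compound 2 `Cc1ccc2c(c1C)CN(CCCN)CC2c1ccccc1` gives 2420 nM, the lower of the two numbers so far. Going by the values given here, the only measured step, a 2.6-fold lower number from compound 1 to compound 2 (0.41 log units; beyond the scatter), is modest and puts 3-aminopropyl in place of isopropyl on an amine nitrogen in a ring. Compound 3 `Cc1ccc2c(c1C)CN(CCCCN)CC2c1ccccc1` carries 4-aminobutyl at that nitrogen instead of 3-aminopropyl: aminomethyl in place of amino on a saturated chain carbon, three bonds along the chain from an amine nitrogen in a ring. The measured step bears on this only indirectly, as it replaces isopropyl and does not extend an amino-bearing chain. Among the compounds with values here, no measurement yet shows what lengthening such a chain does. A step beyond the scatter in this assay is therefore not expected, and neither direction is favoured with any confidence. The expected change is a 1.1-fold lower number from compound 2 to compound 3 (0.04 log units; within the scatter). For compound 3 the estimated value is 2200 nM, with an expected range of 900 nM to 5200 nM.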

Compound 3, half-maximal inhibitory concentration: 2370 nM
Beside the measured number, compound 3's estimate is 1.1-fold (0.03 log units) below it; the range from low to high includes it.
By their numbers in this assay, from the lowest: compounds 3 and 2 (each within the scatter of the next); then compound 1.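

In this assay, extending 3-aminopropyl to 4-aminobutyl gives a 1.0-fold lower number from compound 2 to compound 3 (0.01 log units; within the scatter), so this read-out does not separate the two chain lengths at this position. Replacing isopropyl with 4-aminobutyl gives a 2.6-fold lower number from compound 1 to compound 3 (0.42 log units; beyond the scatter), so the step away from isopropyl now holds for two amino-bearing chains and not for 3-aminopropyl alone. No measured evidence bears on why the two chains read alike.

Still open, going by these compounds, is whether the number holds with a shorter chain such as 2-aminoethyl, a chain longer than 4-aminobutyl, or a chain ending in a carboxylic acid. Also open, on these data alone, is whether the terminal amine or the chain itself accounts for the step from isopropyl, a question that a plain butyl chain would help to settle.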